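Dechlorination of the pyridyl diazepane: expected efficacy

The source may report more compounds than this note shows. Statements on the series, on what has been measured and on what is new or still open speak of the compounds shown alone.

Compound 1 `Clc1cncc(N2CCCNCCC2)c1` gives 103% in an assay on HEK293 cells with Neuronal acetylcholine receptor; alpha4/beta2 (Homo sapiens) as the target, read by FLIPR and calcium flux (on this read-out higher numbers stand for larger maximal responses and lower numbers for smaller maximal responses), and stands highest of the three measured compounds. Compound 2 `COc1cncc(N2CCCNCC2)c1` gives 66% in this assay, and compound 3 `c1ccc2ncc(N3CCCNCC3)cc2c1` gives 33% in this assay; both gaps to compound 1 lie beyond the scatter. Compound 4 `c1cncc(N2CCCNCCC2)c1` differs from compound 1 by hydrogen in place of chloro on an aromatic carbon. Among the measured compounds shown here, no step between measured compounds isolates this change, so the expectation rests on the whole set: substitution on the shared core at this place accompanies the largest response, and its removal is expected to lower the response by a moderate step, estimated as a number 23 percentage points lower from compound 1 to compound 4 (beyond the scatter) in this assay. Compound 4 is therefore estimated at 80% in this assay, expected between 55% and 105%.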

Compound 4, largest response reached (reported as efficacy), in percent of the reference or control that the assay uses: 78%
Compound 4: the middle estimate sits 2 percentage points above what was measured; the range from low to high includes it.
By their numbers in this assay, from the lowest: compound 3; then compound 2; then compound 4; then compound 1.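

In this assay, among the compounds shown here, hydrogen in place of chloro on this aromatic carbon, two atoms from the ring nitrogen, gives a number 25 percentage points lower from compound 1 to compound 4 (beyond the scatter), the first direct reading of this change on the shared core. Chloro is therefore not required for a response, since compound 4 still gives 78%, but its presence accompanies the larger one. Nothing available bears on the reason for this step.

On these data alone, whether bromo, methyl or an amine at this place would match chloro or hydrogen remains open. As far as these compounds go, whether the step carries over to the cores of compound 2 and compound 3 also remains open.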